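This account rests on a few compounds, and the source may have more. Where it says the series, first, only, none or still open, it means among the compounds named here.

Measured in a functional assay on the whole organism with Rattus norvegicus as the target; a lower number here means that less compound is needed, a higher number that more compound is needed for the effect:
- compound 1 `CNc1cc(OC)c(C(=O)NCCN(C)Cc2ccccc2)cc1Cl`: 0.21 mg/kg
- compound 2 `COc1cc(N(C)C)c(Cl)cc1C(=O)NCCN(C)Cc1ccccc1`: 0.54 mg/kg

Compound 2 has the higher of the two numbers, at 0.54 mg/kg. Compound 3 `COc1ccc(Cl)cc1C(=O)NCCN(C)Cc1ccccc1` has hydrogen in place of dimethylamino on an aromatic carbon. Going by the values given here, the only measured step bearing on this is modest: a 2.6-fold higher number from compound 1 to compound 2 (0.41 log units; beyond the scatter). That step alters the substituents on this nitrogen but keeps the nitrogen, whereas compound 3 loses the whole group, so it is only a weak guide. A larger step towards a higher number is therefore expected, though with wide uncertainty. The expected change is an 11-fold higher number from compound 2 to compound 3 (1.05 log units; beyond the scatter). For compound 3 the estimate is 6 mg/kg, with an expected range of 1.2 mg/kg to 30 mg/kg.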

Compound 3, dose for half-maximal effect: 3 mg/kg
For compound 3 the middle estimate is 2.0-fold (0.30 log units) above the measured one, and the stated range covers the measured number.
By their numbers in this assay, from the lowest: compound 1; then compound 2; then compound 3.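

Taking the group away altogether matters more than changing it: replacing dimethylamino with hydrogen gives a 5.6-fold higher number from compound 2 to compound 3 (0.74 log units; beyond the scatter), and replacing methylamino with hydrogen gives a 14-fold higher number from compound 1 to compound 3 (1.15 log units; beyond the scatter), the largest step here. In this assay, compound 1 and compound 2, which both keep a nitrogen on this aromatic carbon, therefore need less compound than compound 3, which has hydrogen there. No measurement offered here explains this difference. Going by these compounds, it remains open whether a nitrogen is needed at this carbon at all, since a primary amine, a methyl group or a methoxy group there could answer that.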